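Compound 3: a hydroxylated ring amide on the shared core

The compounds below may be only part of what the source reports. "The series", "measured", "known", "first", "only" and "open" are said of these compounds alone.

In a physicochemical assay for lipophilicity, measured as octanol-water partition, at pH 7.4 (on this read-out lower numbers stand for lower lipophilicity and higher numbers for higher lipophilicity), compound 1 `CC(C)c1noc(N2CCC(Oc3cc(N4CCc5cc(C6CCCCC6=O)ccc54)ncn3)CC2)n1` gives 4.7. Going by the values given here, compound 2 `CC(=O)N(C)c1ccc2c(c1)CCN2c1cc(OC2CCN(c3nc(C(C)C)no3)CC2)ncn1` gives 3.7 as the lower of the two numbers so far. The gap between the two lies beyond the scatter. Compound 3 `CC(C)c1noc(N2CCC(Oc3cc(N4CCc5cc(N6CCC(O)CC6=O)ccc54)ncn3)CC2)n1` carries 4-hydroxy-2-oxopiperidin-1-yl in place of acetyl(methyl)amino on an aromatic carbon, with 4-hydroxy-2-oxopiperidin-1-yl in place of acetyl(methyl)amino on an aromatic carbon as the counted difference. Among the compounds with values here, the one measured step at this place is the modest a number 1.00 log units lower from compound 1 to compound 2 (beyond the scatter) for acetyl(methyl)amino in place of 2-oxocyclohexyl, a different exchange that guides size only. A smaller downward step in this assay is expected, estimated as a number 0.40 log units lower from compound 2 to compound 3 (beyond the scatter) in size. Compound 3 is expected at 3.3 with a range from 2.8 to 3.8 in this estimate.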

Compound 3, distribution coefficient: 2.8
For compound 3 the middle estimate is 0.50 log units above the measured one; the range from low to high includes it.
By their numbers in this assay, from the lowest: compound 3; then compound 2; then compound 1.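

At this aromatic carbon, 4-hydroxy-2-oxopiperidin-1-yl gives the lowest number of the three in this assay, with a number 0.90 log units lower from compound 2 to compound 3 (beyond the scatter) and a number 1.90 log units lower from compound 1 to compound 3 (beyond the scatter). A six-membered ring here does not by itself set a high number: 2-oxocyclohexyl in compound 1 and 4-hydroxy-2-oxopiperidin-1-yl in compound 3 stand at opposite ends of the series. No measurement on hand accounts for these steps.

The compounds shown do not separate the hydroxyl from the ring amide. Plain 2-oxopiperidin-1-yl, or an amine on the same carbon, would be the next comparison.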